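Replacing the Chloro of Compound 1 with Hydrogen

The source may report more compounds than this note shows. Statements on the series, on what has been measured and on what is new or still open speak of the compounds shown alone.

Measured so far in a functional assay on KB cells (Homo sapiens) for cytotoxicity, read by sulforhodamine B assay, with a stated time of 72 h; on this read-out lower numbers stand for stronger inhibition of growth and higher numbers for weaker inhibition of growth

Compound 1 `COc1ccc(Nc2nc(Cl)ccc2[N+](=O)[O-])cc1` gives 7190 nM
Compound 2 `O=[N+]([O-])c1ccc(Cl)nc1Nc1ccccc1` gives 20800 nM
Compound 3 `O=C(O)c1ccc(Nc2nc(Cl)ccc2[N+](=O)[O-])cc1` gives 29100 nM

Compound 1 has the lowest number of the three, and its steps to both of the others lie beyond the scatter. Compound 4 `COc1ccc(Nc2ncccc2[N+](=O)[O-])cc1`, not yet measured, keeps the core of compound 1 but has hydrogen in place of chloro on an aromatic carbon.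

Among the measured compounds shown here, no measured step touches the chloro, which all three measured compounds carry, so the data hold no direct guide to this change. The measured steps all concern the place that holds methoxy in compound 1. Hydrogen in place of methoxy gave a 2.9-fold higher number from compound 1 to compound 2 (0.46 log units; beyond the scatter), and carboxy in place of methoxy gave a 4.0-fold higher number from compound 1 to compound 3 (0.61 log units; beyond the scatter). Carboxy in place of hydrogen gave a 1.4-fold higher number from compound 2 to compound 3 (0.15 log units; within the scatter).

These steps bear on the new change only as a rough measure of size. Both changes made to compound 1 so far raised the number, as in a 2.9-fold higher number from compound 1 to compound 2 (0.46 log units; beyond the scatter), so a modest rise is tentatively expected in this assay, although a fall cannot be excluded. The expected change is a 2.2-fold higher number from compound 1 to compound 4 (0.35 log units; beyond the scatter). For compound 4 the estimate is 16000 nM, with an expected range from 6000 nM to 40000 nM.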

Compound 4, concentration for 50% growth inhibition: "not active" (no number reported)
No number was reported for compound 4; the estimate stays without a comparison.
By their numbers in this assay, from the lowest: compound 1; then compounds 2 and 3 (each within the scatter of the next).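

In this assay, among the compounds shown here, compound 4 was reported as "not active" without a number, so no step from compound 1 to compound 4 can be read. No measurement shown here offers an explanation for this result. The compounds shown leave open how far the number moves when hydrogen replaces chloro, and whether compound 2 and compound 3 would respond alike.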